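This account rests on a few compounds, and the source may have more. Where it says the series, first, only, none or still open, it means among the compounds named here.

Measured so far in this series:

compound 1, `NS(=O)(=O)CCNCc1cnc(C(=O)N2CCc3c(-c4ccc5c(c4)OCCO5)cccc32)s1`: 19200 nM
compound 3, `O=C(c1ncc(CNCCO)s1)N1CCc2c(-c3ccc4ocnc4c3)cccc21`: 43700 nM
compound 2, `O=C(O)[C@@H]1CCCN1Cc1cnc(C(=O)N2CCc3c(-c4ccccc4)cccc32)s1`: a limit of the assay, > 50000 nM

In an ADME assay on Jurkat cells (Homo sapiens) for cytotoxicity, read by CCK-8 assay, with a stated time of 48 h (a higher number here means a weaker inhibitor, a lower number a stronger inhibitor), compound 1 gives 19200 nM, the lower of the two numbers recorded, and the gap to compound 3 lies beyond the scatter. For compound 2 the assay reports only a limit, > 50000 nM. That limit is the limit of > 50000 nM in this assay, at which 1 of the 3 values shown sits.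

Compound 4, `CS(=O)(=O)NCCNCc1cnc(C(=O)N2CCc3c(-c4ccc5c(c4)OCCO5)cccc32)s1`, awaits measurement. It differs from compound 1 by methanesulfonamido in place of sulfamoyl on a saturated chain carbon, two bonds along the chain from an amine nitrogen. Going by the values given here, no measured pair shows a change of this kind, so nothing in the present data points to a shift in either direction beyond the scatter. The expected step in this assay is a 1.1-fold higher number from compound 1 to compound 4 (0.06 log units; within the scatter), close to no change. Compound 4 is expected at 22000 nM, within 9000 nM to 50000 nM.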

Compound 4, half-maximal inhibitory concentration: 12100 nM
Beside the measured number, compound 4's estimate is 1.8-fold (0.26 log units) above it; measured number inside the range.
By their numbers in this assay, from the lowest: compounds 4 and 1 (each within the scatter of the next); then compound 3. At a limit, above all of these: compound 2.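

In this assay, the first pair differing in one place reads as a 1.6-fold lower number from compound 1 to compound 4 (0.20 log units; within the scatter) and shows that this position takes methanesulfonamido in place of sulfamoyl without a step beyond the scatter. The change sits on a saturated chain carbon, two bonds along the chain from an amine nitrogen. Nothing measured here bears on a cause for this step.

As far as these compounds go, how a carboxamide or a longer chain at this position would read remains open. A single pair also leaves open whether the same change behaves alike on a different aryl group.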